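Methoxy for methyl on the benzoyl ring: low toxicity expected

The compounds below may be only part of what the source reports. "The series", "measured", "known", "first", "only" and "open" are said of these compounds alone.

Compound 3 `Cc1ccc(C(=O)NC(=S)N2CCc3c(OCCCCCOc4ccc(Cl)cc4)cccc32)cc1` gives in an ADME assay on Huh-7 cells (Homo sapiens) for cytotoxicity (on this read-out lower numbers stand for higher toxicity in this test and higher numbers for lower toxicity in this test), only a limit, > 50000 nM (the limit of > 50000 nM in this assay, at which 1 of the 3 values shown sits). Compound 1 `O=C(NC(=S)N1CCc2c(OCCCCCOc3ccc(Cl)cc3)cccc21)c1cccc([N+](=O)[O-])c1` gives 12100 nM in this assay, and compound 2 `O=C(NC(=S)N1CCc2c(OCCCCCOc3ccc(Cl)cc3)cccc21)c1ccc(Br)cc1` gives 29100 nM. The change from compound 3 to compound 4 `COc1ccc(C(=O)NC(=S)N2CCc3c(OCCCCCOc4ccc(Cl)cc4)cccc32)cc1` is methoxy in place of methyl on an aromatic carbon. The measured steps that bear on this ring are a 2.4-fold higher number from compound 1 to compound 2 (0.38 log units; beyond the scatter), an at least 4.1-fold higher number from compound 1 to compound 3 (0.61 log units; beyond the scatter) and an at least 1.7-fold higher number from compound 2 to compound 3 (0.23 log units; that floor lies within the scatter); each of them is modest at most, and none is large. Compound 4 is therefore expected to stay at or near the limit in this assay, with a step that the limit leaves unreadable from compound 3 to compound 4 estimated as no step beyond the scatter. The estimate for compound 4 is 60000 nM, ranging from 25000 nM to 150000 nM.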

Compound 4, half-maximal cytotoxic concentration: 34400 nM
Beside the measured number, compound 4's estimate is 1.7-fold (0.24 log units) above it, within the range that was stated.
By their numbers in this assay, from the lowest: compound 1; then compounds 2 and 4 (each within the scatter of the next). At a limit, above all of these: compound 3.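

In this assay, methoxy in place of methyl gives an at least 1.4-fold lower number from compound 3 to compound 4 (0.16 log units; that floor lies within the scatter), a floor that does not separate the two groups at this place. Methoxy in place of bromo gives a 1.2-fold higher number from compound 2 to compound 4 (0.07 log units; within the scatter), so these two groups are not told apart either. Only the change from the 3-nitrophenyl group stands out, with a 2.8-fold higher number from compound 1 to compound 4 (0.45 log units; beyond the scatter).

Going by these compounds, compound 3 remains a limit rather than a number, so the true gap between methyl and methoxy stays unread: the limit of > 50000 nM in this assay, at which 1 of the 4 values shown sits. Whether an amine, a carboxylic acid or a longer ether chain such as butoxy at this place would keep the number this high remains open.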